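Carbonyl aryl swap on thiocarbamate series: cytotoxicity outlook

The compounds below may be only part of what the source reports. "The series", "measured", "known", "first", "only" and "open" are said of these compounds alone.

Of the compounds shown here, three sharing a common core have been measured in an ADME assay on MT4 cells (Homo sapiens) for cytotoxicity, read by MTT assay; on this read-out lower numbers stand for higher toxicity in this test and higher numbers for lower toxicity in this test. Compound 1 `O=C1c2ccccc2C(=O)N1CCOC(=S)N(C(=O)c1ccc(Cl)c(Cl)c1)c1ccc(Cl)cc1` gives 35000 nM in this assay. Compound 2 `COc1cccc(OC)c1C(=O)N(C(=S)OCCN1C(=O)c2ccccc2C1=O)c1ccc(Cl)cc1` carries 2,6-dimethoxyphenyl in place of 3,4-dichlorophenyl on a carbonyl carbon and gives 69000 nM in this assay; the step is a 2.0-fold higher number from compound 1 to compound 2 (0.29 log units; within the scatter). Compound 3 `Cc1ccc(N(C(=O)c2ccc(Cl)c(Cl)c2)C(=S)OCCN2C(=O)c3ccccc3C2=O)cc1` differs from compound 1 by methyl in place of chloro on an aromatic carbon. In this assay compound 3 gives 17000 nM, the step being a 2.1-fold lower number from compound 1 to compound 3 (0.31 log units; beyond the scatter). Compound 3 thus stands at the lowest number of the three, with its step to compound 1 and its gap to compound 2 both beyond the scatter.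

Compound 4 `COc1cccc(OC)c1C(=O)N(C(=S)OCCN1C(=O)c2ccccc2C1=O)c1ccc(C)cc1` is not yet measured. It differs from compound 3 by 2,6-dimethoxyphenyl in place of 3,4-dichlorophenyl on a carbonyl carbon. This is the same change already seen between compound 1 and compound 2, and the place line reads the same word for word in both cases, so the two changes are the same change made on cores that differ by methyl in place of chloro on an aromatic carbon. Among the compounds with values here, the one measured instance of it, a 2.0-fold higher number from compound 1 to compound 2 (0.29 log units; within the scatter), lay within the scatter.

The expectation for compound 4 rests on that single pair, because the same change gave a 2.0-fold higher number from compound 1 to compound 2 (0.29 log units; within the scatter), and a step of similar size is expected here, starting from compound 3 at 17000 nM. On that basis the expected step is a 2.0-fold higher number from compound 3 to compound 4 (0.30 log units; within the scatter). Within the data shown here, compound 4 is then estimated at 34000 nM, with a range from 15000 nM to 80000 nM reflecting that only one prior instance of the change is available.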

Compound 4, half-maximal cytotoxic concentration: 36000 nM
Beside the measured number, compound 4's estimate is 1.1-fold (0.02 log units) below it; the range from low to high includes it.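

In this assay, 2,6-dimethoxyphenyl in place of 3,4-dichlorophenyl on a carbonyl carbon gives a 2.1-fold higher number from compound 3 to compound 4 (0.33 log units; beyond the scatter), and this step on the methyl-bearing core agrees with the earlier one on the chloro-bearing core: the same change on two cores in this assay, a 2.0-fold higher number (0.29 log units; within the scatter) from compound 1 to compound 2 and a 2.1-fold higher number (0.33 log units; beyond the scatter) from compound 3 to compound 4, 1.1-fold (0.03 log units) apart, within the scatter of two such steps. The second change, methyl in place of chloro on an aromatic carbon, gives a 1.9-fold lower number from compound 2 to compound 4 (0.28 log units; within the scatter), and it also carries over between the two carbonyl substituents: the same change on two cores in this assay, a 2.1-fold lower number (0.31 log units; beyond the scatter) from compound 1 to compound 3 and a 1.9-fold lower number (0.28 log units; within the scatter) from compound 2 to compound 4, 1.1-fold (0.03 log units) apart, within the scatter of two such steps. Across these four compounds, each change therefore keeps its size when the other is present, but each comparison rests on only two steps of modest size, with one step in each comparison printed as within the scatter, so this does not establish transfer to other cores or other groups.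

The compounds shown leave open whether the same agreement would hold with an amine or a carboxylic acid on the aryl ring at the carbonyl carbon, or with a longer chain in place of the one joining the thiocarbamate oxygen to the rest of the shared core. They also leave open whether the two dimethoxy groups act together, since a phenyl carrying a single methoxy does not appear among them.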